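Adding a Methyl Group to a Second Core

The source may report more compounds than this note shows. Statements on the series, on what has been measured and on what is new or still open speak of the compounds shown alone.

Measured so far in a physicochemical assay for lipophilicity, using the shake flask method, measured as octanol-water partition, with a stated time of 24 h, at 25 degrees C; a lower number here means a more polar compound, a higher number a more lipophilic compound:
- compound 1 `Clc1ccc(CN(Cc2nnn[nH]2)c2ccccc2)c(Cl)c1` gives 1.67
- compound 2 `Cc1ccc(N(Cc2nnn[nH]2)Cc2ccc(Cl)cc2Cl)cc1` gives 1.99
- compound 3 `Fc1ccc(CN(Cc2nnn[nH]2)c2ccccc2)c(F)c1` gives 1.36

Compounds 1 and 2 differ in a single place: methyl in place of hydrogen on an aromatic carbon. This change is linked to a number 0.32 log units higher from compound 1 to compound 2 (beyond the scatter), a step that lies beyond the usual scatter of the method.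

Compound 3 has the lowest number of the three. The difference between the core of compound 3 and the core of compound 1 is not broken down here.

Compound 4 `Cc1ccc(N(Cc2nnn[nH]2)Cc2ccc(F)cc2F)cc1` has not yet been measured. It differs from compound 3 in one place: methyl in place of hydrogen on an aromatic carbon. The place of this change is described in the same words as for the change from compound 1 to compound 2, so it is taken as the same change, made on a different core.

Because the earlier step was a number 0.32 log units higher from compound 1 to compound 2 (beyond the scatter), a step of similar size is expected here, giving an estimated a number 0.32 log units higher from compound 3 to compound 4 (beyond the scatter). This rests on a single earlier example, so the range must stay wide. Starting from compound 3 with its value of 1.36, compound 4 is expected to give about 1.68. The expected range for compound 4 runs from 1.45 to 1.95.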

Compound 4, partition coefficient: 1.42
Compound 4: the middle estimate sits 0.26 log units above what was measured; the whole stated range lies above it.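

In this assay, putting methyl in place of hydrogen on an aromatic carbon, here phenyl to 4-methylphenyl, gives a number 0.06 log units higher from compound 3 to compound 4 (within the scatter) on the core of compound 3, while the change described in the same words gives a number 0.32 log units higher from compound 1 to compound 2 (beyond the scatter) on the core of compound 1. For the compounds shown here, the step that stood beyond the scatter on one core therefore did not carry over to the other core in this pair, where the two measured numbers cannot be told apart from ordinary repeat variation; this shows that the methyl step cannot simply be transferred from one of these cores to the other, but with only two matched pairs it does not show how the change would behave on any further core, or that it has no effect on the core of compound 3. Nothing measured here explains why the two cores gave different readings, so the result remains an observation without a known cause.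

The compounds shown leave open what a longer chain such as ethyl, or an amine, would do in the same place on these two cores. Going by these compounds alone, they also leave open whether the methyl change on a third core would resemble the step seen from compound 1 to compound 2 or the one seen from compound 3 to compound 4.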